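Swapping a Methyl for Chloro and Fluoro on the Sulfonamide Ring

The compounds below may be only part of what the source reports. "The series", "measured", "known", "first", "only" and "open" are said of these compounds alone.

Of the compounds shown here, three sharing one core have been tested in a functional assay on CFPAC-1 cells (Homo sapiens) for antiproliferative activity, read by MTT assay, with a stated time of 72 h; a lower number here means a stronger inhibitor, a higher number a weaker inhibitor. Compound 1 `O=C1O[C@H]([C@@H](O)Cn2cc(CNS(=O)(=O)c3ccc(F)cc3)nn2)C(OCc2ccccc2)=C1OCc1ccccc1` gives 34700 nM, compound 2 `O=C1O[C@H]([C@@H](O)Cn2cc(CNS(=O)(=O)c3ccc(Cl)cc3)nn2)C(OCc2ccccc2)=C1OCc1ccccc1` gives 38900 nM, and compound 3 `Cc1ccc(S(=O)(=O)NCc2cn(C[C@H](O)[C@H]3OC(=O)C(OCc4ccccc4)=C3OCc3ccccc3)nn2)cc1` gives 68000 nM. Compound 3 carries the highest of the three numbers, yet every step toward it stays within the scatter: a 2.0-fold higher number from compound 1 to compound 3 (0.29 log units; within the scatter) and a 1.7-fold higher number from compound 2 to compound 3 (0.24 log units; within the scatter), so no real order among the three can be claimed.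

Compound 4 `O=C1O[C@H]([C@@H](O)Cn2cc(CNS(=O)(=O)c3ccc(Cl)cc3F)nn2)C(OCc2ccccc2)=C1OCc1ccccc1` has not yet been measured. It differs from compound 3 by 4-chloro-2-fluorophenyl in place of 4-methylphenyl on a sulfonyl sulfur. The ring that enters carries the chloro of compound 2 together with a fluoro like that of compound 1, while the methyl of compound 3 leaves. Among the measured compounds shown here, the steps that bear on this are the ones between compound 3 and its two neighbours: a 1.7-fold higher number from compound 2 to compound 3 (0.24 log units; within the scatter) and a 2.0-fold higher number from compound 1 to compound 3 (0.29 log units; within the scatter), neither of which rose beyond the scatter. Undoing the methyl and putting back a chloro, with an extra fluoro on the same ring, should therefore give at most a small drift, estimated as a 1.7-fold lower number from compound 3 to compound 4 (0.23 log units; within the scatter).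

Compound 4 is expected to give about 40000 nM, within 15000 nM to 100000 nM in this assay.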

Compound 4, half-maximal inhibitory concentration: 58200 nM
For compound 4 the middle estimate is 1.5-fold (0.16 log units) below the measured one; low and high end bracket the measured number.
By their numbers in this assay, from the lowest: compounds 1, 2, 4 and 3 (each within the scatter of the next).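

In this assay the whole-ring exchange on the sulfonyl sulfur, 4-chloro-2-fluorophenyl in place of 4-methylphenyl, gives a 1.2-fold lower number from compound 3 to compound 4 (0.07 log units; within the scatter) and so the two rings cannot be told apart. Among the compounds shown here, compound 4 also adds something the earlier compounds lacked, a second halogen on the ring: fluoro in place of hydrogen on an aromatic carbon gives a 1.5-fold higher number from compound 2 to compound 4 (0.17 log units; within the scatter) and 4-chloro-2-fluorophenyl in place of 4-fluorophenyl gives a 1.7-fold higher number from compound 1 to compound 4 (0.22 log units; within the scatter) and neither step can be separated from repeat-measurement noise. Across these four compounds, then, a ring with one methyl, one halogen or two halogens reads alike at this position, and no measurement here offers an explanation for that.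

All four compounds carry a substituted phenyl ring on the sulfonyl sulfur, and the rest of the shared core stays the same throughout. Still open, on these data alone, is whether this position would respond to a group of a different kind on that ring, such as an amine or a carboxylic acid, or to a longer chain in place of the ring.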